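A few compounds are considered here, and "the series" means these few. Any claim that something is new, unique, unknown or untested is made for them only; others in the source may bear on it.

Measured in a functional assay on MOLT-4 cells (Homo sapiens) for inhibition, read by MTT assay, with a stated time of 72 h; a lower number here means a stronger inhibitor, a higher number a weaker inhibitor:

- Compound 1 `COc1cc(NC(C)CCCNC(=O)Nc2cccc(Cl)c2)c2ncccc2c1` gives 21000 nM
- Compound 2 `COc1cc(NC(C)CCCNC(=O)NNC(=O)Nc2ccc(F)cc2)c2ncccc2c1` gives >= 250000 nM, which is a limit of the assay and not a number
- Compound 3 `COc1cc(NC(C)CCCNC(=O)Nc2ccc(C(F)(F)F)cc2)c2ncccc2c1` gives 20000 nM

Compound 3 cannot be told apart from compound 1, as a 1.1-fold lower number from compound 1 to compound 3 (0.02 log units; within the scatter) shows, and it stands well clear of the limit reached by compound 2, with an at least 12-fold lower number from compound 2 to compound 3 (1.09 log units; beyond the scatter).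

Compound 4 `COc1cc(NC(C)CCCNC(=O)NNC(=O)Nc2cccc(Cl)c2)c2ncccc2c1` has ((3-chlorophenyl)carbamoyl)amino in place of 4-(trifluoromethyl)phenyl on an amide-type nitrogen.

Among the compounds with values here, the closest precedent is compound 2, which carries the related ((4-fluorophenyl)carbamoyl)amino group. Bringing that group in gave an at least 11-fold higher number from compound 1 to compound 2 (1.07 log units; beyond the scatter), a large step. Exchanging 3-chlorophenyl for 4-(trifluoromethyl)phenyl, by contrast, gave only a 1.1-fold lower number from compound 1 to compound 3 (0.02 log units; within the scatter), so the longer group is expected to dominate. The step expected in this assay is therefore large and towards a higher number: a 6.0-fold higher number from compound 3 to compound 4 (0.78 log units; beyond the scatter). The result may also arrive only as a limit. For compound 4 the estimated value is 120000 nM, with an expected range from 40000 nM to 300000 nM.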

Compound 4, half-maximal inhibitory concentration: 93000 nM
Estimate against measurement, compound 4: 1.3-fold (0.11 log units) above; the range from low to high includes it.
By their numbers in this assay, from the lowest: compounds 3 and 1 (each within the scatter of the next); then compound 4. At a limit, above all of these: compound 2.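

In this assay, the longer ((3-chlorophenyl)carbamoyl)amino group on the amide-type nitrogen gives a measurable size for this kind of change, which compound 2 alone could not: a 4.4-fold higher number from compound 1 to compound 4 (0.65 log units; beyond the scatter) and a 4.7-fold higher number from compound 3 to compound 4 (0.67 log units; beyond the scatter), both modest steps towards weaker inhibition. The aromatic end of the longer group also matters, as 3-chlorophenyl in place of 4-fluorophenyl gives an at least 2.6-fold lower number from compound 2 to compound 4 (0.42 log units; beyond the scatter), a step that rests on a limit and so gives only its smallest possible size. The value of compound 2 is a limit of the assay and not a number: the limit of >= 250000 nM in this assay, at which 1 of the 4 values shown sits.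

These two groups differ in both the halogen and its place on the ring, so the two effects remain unseparated. As far as these compounds go, whether a plain phenyl or a carboxylic acid on that ring would keep activity near that of compound 4 also remains open.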